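The source may report more compounds than this note shows. Statements on the series, on what has been measured and on what is new or still open speak of the compounds shown alone.

Measured so far, in a functional assay on CCRF-CEM cells (Homo sapiens) for cytotoxicity, in the absence of a further agent; on this read-out lower numbers stand for stronger inhibition and higher numbers for weaker inhibition:
- compound 1 `Nc1nc(N)c(CCCNc2cc(F)cc(F)c2[N+](=O)[O-])c(O)n1`: 97000 nM
- compound 2 `CC(C)(C)OC(=O)CCC(Nc1ccc(CN(CCCc2c(N)nc(N)nc2O)c2cc(F)cc(F)c2[N+](=O)[O-])cc1)C(=O)OC(C)(C)C`: 17000 nM
- compound 3 `Nc1nc(N)c(CCCN(Cc2ccc(NC(CCC(=O)O)C(=O)O)cc2)c2cc(F)ccc2[N+](=O)[O-])c(O)n1`: limit, > 100000 nM

Compound 2 gives the lowest of the two numbers in this assay; compound 1, the nearest of them, gives a higher number, and the gap between the two lies beyond the scatter. Compound 3 yields only a limit in this assay, > 100000 nM, so no number is known for it. the limit of > 100000 nM in this assay, at which 1 of the 3 values shown sits.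

Compound 4 `CC(C)(C)OC(=O)CCC(Nc1ccc(CN(CCCc2c(N)nc(N)nc2O)c2ccc([N+](=O)[O-])c(F)c2F)cc1)C(=O)OC(C)(C)C` has not yet been measured in this assay. It has the same atoms as compound 2, joined differently: 2,3-difluoro-4-nitrophenyl in place of 3,5-difluoro-2-nitrophenyl on an amine nitrogen. Among the compounds with values here, no measured pair shares this change, so no measured step guides the size of the effect. Both compounds keep the shared core and the same bis-ester chain; only the pattern of the two fluorines and the nitro group on the aryl ring attached to the amine nitrogen moves. With nothing measured to anchor the move, the expectation is a small to moderate loss or no change beyond the scatter, with the limit also possible. On this basis the step from compound 2 to compound 4 is estimated at a 1.8-fold higher number from compound 2 to compound 4 (0.25 log units; within the scatter). Compound 4 is therefore expected to give about 30000 nM in this assay, within a range of 8000 nM to 100000 nM.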

Compound 4, half-maximal inhibitory concentration: 36000 nM
Estimate against measurement, compound 4: 1.2-fold (0.08 log units) below; low and high end bracket the measured number.
By their numbers in this assay, from the lowest: compound 2; then compound 4; then compound 1. At a limit, above all of these: compound 3.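

In this assay, within the data shown here, the first measured step at this position shows that the aryl group on the amine nitrogen is not indifferent to its substitution pattern. With the atom count and the bis-ester chain unchanged, putting 2,3-difluoro-4-nitrophenyl in place of 3,5-difluoro-2-nitrophenyl gives a 2.1-fold higher number from compound 2 to compound 4 (0.33 log units; beyond the scatter), a modest step that lies beyond the scatter, and 3,5-difluoro-2-nitrophenyl holds the lower number of this pair. Nothing on hand accounts for the size or direction of this step.

The nitro group and the two fluorines change places together in this single step, so the share of each cannot be told apart, and a phenyl group carrying only fluorines, or a nitrile in place of the nitro group, would be needed to separate them. On these data alone, it also stays open whether the same exchange gives a step of similar size and direction with the free dicarboxylic acid chain in place of the bis-ester chain, or with a chain other than these two.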